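Trimming an ethoxy to methoxy in a weakly cytotoxic pair

The source may hold more compounds than are shown below. What is called first, only, known or untested is meant among the compounds shown, and "the series" means these compounds.

Measured compounds:
Compound 1, `CCOc1cc([C@H]2SCC(=O)N2NC(=O)c2nccnc2N)ccc1O`: 84.2 ug/mL
Compound 2, `CCOc1cc([C@@H]2SCC(=O)N2NC(=O)c2cnc(C)cn2)ccc1O`: > 100 ug/mL

In an ADME assay on A549 cells (Homo sapiens) for cytotoxicity, read by MTT assay, with a stated time of 3 days (a lower number here means a stronger inhibitor, a higher number a weaker inhibitor), compound 1 gives 84.2 ug/mL. Compound 2 gives > 100 ug/mL, which is a limit of the assay and not a number. On these data alone, compound 2 therefore stands at the limit of > 100 ug/mL in this assay, at which 1 of the 2 values shown sits, so its true value is unknown beyond that bound, and what the pair shows is simply that neither compound is a strong inhibitor here.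

Compound 3, `COc1cc([C@@H]2SCC(=O)N2NC(=O)c2cnc(C)cn2)ccc1O`, shares the core of compound 2 and differs in one place: hydrogen in place of methyl on a saturated chain carbon bound to an oxygen on an aromatic ring. Going by the values given here, no measured pair shows what such a change does in this assay. Since compound 2 sits at the limit, a change of this small size is expected to leave compound 3 also weak, with a step from compound 2 to compound 3 estimated at a number no higher from compound 2 to compound 3 (the limit leaves the size open), which is none beyond the scatter. Compound 3 is accordingly expected to give about 100 ug/mL, within a range from 50 ug/mL to 200 ug/mL, most likely reported again only as a limit.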

Compound 3, half-maximal inhibitory concentration: 62.3 ug/mL
Beside the measured number, compound 3's estimate is 1.6-fold (0.21 log units) above it; the measured number falls inside the stated range.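

Going by these compounds alone, compound 3 gives the first reading of what a change at this place does, on a saturated chain carbon bound to an oxygen on an aromatic ring: in this assay, trimming ethoxy to methoxy comes with an at least 1.6-fold lower number from compound 2 to compound 3 (0.20 log units; that floor lies within the scatter). Compound 2 gives > 100 ug/mL, which is a limit of the assay and not a number. The step is therefore only a floor, so the real effect of losing this one carbon may lie within the scatter or beyond it, and a single trim cannot settle that because the comparison rests on a bound and not on two numbers: the limit of > 100 ug/mL in this assay, at which 1 of the 3 values shown sits.

The compounds shown leave open how a longer chain at this place, such as propoxy, or a free hydroxyl in place of the ethoxy would read in this assay, and so whether any trend follows chain length at all. They also leave open whether the same trim from ethoxy to methoxy would give a similar step on compound 1 , which carries a different group on the other side of its amide.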